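The compounds below may be only part of what the source reports. "The series", "measured", "known", "first", "only" and "open" are said of these compounds alone.

Of the compounds shown here, two have been measured in a functional assay on BJAB cells (Homo sapiens) for antiproliferative activity, with a stated time of 4 days; a higher number here means that more compound is needed for the effect, a lower number that less compound is needed. Compound 1 `Cc1nn(-c2nc(-c3ccc(Cl)c(Cl)c3)c(SC(C)C)s2)c(C(=O)O)c1-c1ccc(Cl)cc1` gives 2500 nM, the lowest of the two numbers seen in this assay. Compound 2 `COC(=O)c1c(Cc2ccccc2[N+](=O)[O-])c(C)nn1-c1nc(-c2ccc(Cl)c(Cl)c2)c(SC(C)C)s1` gives 93000 nM, a far higher number, beyond the scatter. The step followed here leads from compound 1 to compound 3 `COc1cccc(-c2c(C)nn(-c3nc(-c4ccc(Cl)c(Cl)c4)c(SC(C)C)s3)c2C(=O)O)c1`, which has not yet been measured. The change is 3-methoxyphenyl in place of 4-chlorophenyl on an aromatic carbon. For the measured compounds named here, no measured pair shows this change, so its effect can only be expected, not read from the numbers. The expected step is a 1.8-fold higher number from compound 1 to compound 3 (0.26 log units; within the scatter), a move toward a higher number that sits at the edge of the scatter rather than clearly beyond it. Compound 3 is therefore estimated to give 4500 nM in this assay, with a range from 1500 nM to 14000 nM.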

Compound 3, half-maximal effective concentration: 14000 nM
Beside the measured number, compound 3's estimate is 3.1-fold (0.49 log units) below it; the measured number falls inside the stated range.
By their numbers in this assay, from the lowest: compound 1; then compound 3; then compound 2.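

In this assay, for the compounds shown here, 3-methoxyphenyl in place of 4-chlorophenyl gives a 5.6-fold higher number from compound 1 to compound 3 (0.75 log units; beyond the scatter), the only step here that reads this position directly. This aromatic carbon, next to the ring atom that bears a carboxy group and next to the ring atom that bears a methyl group, therefore does not take these two aryl groups interchangeably, and of the two, 4-chlorophenyl goes with the lower number. Nothing available explains this step.

The step swaps both the substituent and where it sits on the phenyl ring, so it cannot show which of the two matters; 3-chlorophenyl or 4-methoxyphenyl at this carbon would separate them. Also open, on these data alone, is how an unsubstituted phenyl would read here, and whether the same step would hold with an amide in place of the carboxy group.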